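Azido in place of hydroxyethylamino on the shared core

A few compounds are considered here, and "the series" means these few. Any claim that something is new, unique, unknown or untested is made for them only; others in the source may bear on it.

In a functional assay (Homo sapiens) for inhibition of Nucleic Acid, tested at 100 uM (on this read-out lower numbers stand for less inhibition and higher numbers for more inhibition at the one concentration tested (going by the name of the read-out)), compound 1 `CSc1nccc2c1ncn2C1O[C@H](CO)[C@@H](O)[C@H]1O` gives 24%, compound 2 `CCNc1nccc2c1ncn2C1O[C@H](CO)[C@@H](O)[C@H]1O` gives 4%, and compound 3 `OCCNc1nccc2c1ncn2C1O[C@H](CO)[C@@H](O)[C@H]1O` gives 0%. Compound 3 thus stands at the low end of the three numbers: compound 2 lies within the scatter of it, while compound 1 lies beyond it. Compound 4 `[N-]=[N+]=Nc1nccc2c1ncn2C1O[C@H](CO)[C@@H](O)[C@H]1O` differs from compound 3 by azido in place of (2-hydroxyethyl)amino on an aromatic carbon. Two measured steps on the same aromatic carbon bear on this change: a number 24 percentage points lower from compound 1 to compound 3 (beyond the scatter) and a number 4 percentage points lower from compound 2 to compound 3 (within the scatter). Neither involves an azido group, so the direction remains uncertain. The expected step is a number 10 percentage points higher from compound 3 to compound 4 (within the scatter), roughly the size of the scatter. Compound 4 is therefore estimated at 10%, with a range from 0% to 35%.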

Compound 4, a percentage reported as inhibition, at one concentration (the size of the read-out at that concentration, not a potency): 4%
Compound 4: the middle estimate sits 6 percentage points above what was measured; the measured number falls inside the stated range.
By their numbers in this assay, from the lowest: compounds 3, 2 and 4 (each within the scatter of the next); then compound 1.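

In this assay azido on this aromatic carbon falls with the two amino groups, not with methylsulfanyl: the reading is a number 4 percentage points higher from compound 3 to compound 4 (within the scatter) and no change at the digits printed from compound 2 to compound 4 (within the scatter), while it is a number 20 percentage points lower from compound 1 to compound 4 (beyond the scatter). Among the four groups shown here, methylsulfanyl alone stands apart, and a non-amino group does not share its higher number. Nothing available gives a reason for this. The compounds shown leave open whether another sulfur group, such as ethylsulfanyl, would match methylsulfanyl, and where a chlorine or an unsubstituted amine would fall.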